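The source may hold more compounds than are shown below. What is called first, only, known or untested is meant among the compounds shown, and "the series" means these compounds.

Measured so far:

Compound 1 `CCOC(=O)c1ccc(Oc2ccc(OC)cc2)cc1`. In a functional assay on HL-60 cells (Homo sapiens) for antiproliferative activity (a higher number here means a weaker inhibitor, a lower number a stronger inhibitor), compound 1 gives > 20000 nM, which is a limit of the assay rather than a number.

Compound 2 `CCOC(=O)c1ccc(Oc2ccc(OC)c(OC)c2)cc1`. In this assay compound 2 gives > 20000 nM, likewise a limit.

Compound 3 `COC(=O)c1ccc(Oc2ccc(OC)cc2)c(N)c1`. In this assay compound 3 gives > 20000 nM, again a limit.

The change from compound 1 to compound 2 is methoxy in place of hydrogen on an aromatic carbon. The step that the two limits leave unreadable from compound 1 to compound 2 is unreadable because both values sit at the limit of > 20000 nM in this assay, at which 3 of the 3 values shown sit. Compound 4 `COC(=O)c1ccc(Oc2ccc(OC)c(OC)c2)c(N)c1` is not yet measured; it stands to compound 3 as compound 2 stands to compound 1, through (methoxy in place of hydrogen on an aromatic carbon), the same change at the same place. How the core of compound 3 differs from that of compound 1 is not broken down here. Among the compounds with values here, with every value sitting at the limit of > 20000 nM in this assay, at which 3 of the 3 values shown sit, no step of known size exists to lean on, and the step of a number no higher from compound 3 to compound 4 (the limit leaves the size open) is expected to be negligible. Compound 4 is therefore estimated at 20000 nM in this assay, between 8000 nM and 50000 nM, most probably again reported only as a limit.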

Compound 4, half-maximal inhibitory concentration: > 20000 nM
Compound 4 gave a limit, no number (the forecaster's own chance of this, stated with the estimate: 85%); the middle value lies on the limit itself.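

No size can be read for the methoxy change between compound 3 and compound 4, because both values are limits of the assay: the limit of > 20000 nM in this assay, at which 4 of the 4 values shown sit.

The compounds shown leave open what size this methoxy change has in this assay, and which structures in the series would give a number there.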